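The source may hold more compounds than are shown below. What is called first, only, known or untested is meant among the compounds shown, and "the series" means these compounds.

Compound 1 `CCCC(Oc1ccc(-n2cc(OC)cn2)cc1)c1ccc(C(=O)NCCC(=O)O)cc1` gives > 23000 nM in a functional assay on cells for antagonist activity at Glucagon receptor (Homo sapiens), read by cAMP accumulation, in the presence of a further agent that is not named here (a lower number here means a stronger inhibitor, a higher number a weaker inhibitor), which is a limit of the assay rather than a number.
Compound 2 `O=C(O)CCNC(=O)c1ccc(C(Oc2ccc(-n3cc(C(F)(F)F)cn3)cc2)C2CCC2)cc1` gives 3000 nM in this assay.
Compound 3 `CCCC(Oc1ccc(-n2cc(F)cn2)cc1)c1ccc(C(=O)NCCC(=O)O)cc1` gives 10000 nM in this assay.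

Among the two numbers measured, compound 3 has the higher one; its nearest neighbour is compound 2, a lower number beyond the scatter. Compound 1 sits at the limit of > 23000 nM in this assay, at which 1 of the 3 values shown sits, and gives no number. Compound 4 `CCCC(Oc1ccc(-n2cc(C(F)(F)F)cn2)cc1)c1ccc(C(=O)NCCC(=O)O)cc1` differs from compound 3 in one place: trifluoromethyl in place of fluoro on an aromatic carbon.

Among the compounds with values here, the only measured step at that position is an at least 2.3-fold lower number from compound 1 to compound 3 (0.36 log units; beyond the scatter), a change toward fluoro that lowered the number at least modestly. Compound 2 also carries trifluoromethyl on that ring and gives 3000 nM, below compound 3, but it differs from compound 4 elsewhere as well, so only the two values can be compared. A further lowering of the number is therefore expected from compound 3 to compound 4, a 2.5-fold lower number from compound 3 to compound 4 (0.40 log units; beyond the scatter). Compound 4 is estimated at 4000 nM in this assay, within 1500 nM to 12000 nM.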

Compound 4, antagonist equilibrium constant: 5100 nM
Beside the measured number, compound 4's estimate is 1.3-fold (0.11 log units) below it, within the range that was stated.
By their numbers in this assay, from the lowest: compounds 2, 4 and 3 (each within the scatter of the next, the first and the last beyond it). At a limit, above all of these: compound 1.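

Trifluoromethyl in place of fluoro on this aromatic carbon gives a 2.0-fold lower number from compound 3 to compound 4 (0.29 log units; within the scatter) in this assay, so the larger group does not separate itself from fluoro at this position. Trifluoromethyl in place of methoxy gives an at least 4.5-fold lower number from compound 1 to compound 4 (0.65 log units; beyond the scatter) and, at the saturated chain carbon, propyl in place of cyclobutyl gives a 1.7-fold higher number from compound 2 to compound 4 (0.23 log units; within the scatter) with trifluoromethyl held on the five-membered ring, so propyl and cyclobutyl cannot be told apart here. The step from methoxy is only a bound, since compound 1 stands at a limit of the assay: the limit of > 23000 nM in this assay, at which 1 of the 4 values shown sits.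

On these data alone, it remains open how a nitrile or a methyl group on this carbon would compare with fluoro and trifluoromethyl. The compounds also leave open what a longer chain than propyl, or an amine in place of the carboxylic acid, would do.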